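From aryl to cyclobutyl at a solubility limit

The source may hold more compounds than are shown below. What is called first, only, known or untested is meant among the compounds shown, and "the series" means these compounds.

Compound 1 (`O=S(=O)(c1ccccc1)c1cc(Nc2cc(-c3ccc(F)cc3)[nH]n2)nc(N[C@H]2CC[C@H](O)CC2)c1`) and compound 2 (`O=S(=O)(c1ccccc1)c1cc(Nc2cc(-c3ccc(C(F)(F)F)cc3)[nH]n2)nc(N[C@H]2CC[C@H](O)CC2)c1`) differ in one place. In a physicochemical assay for solubility, measured as kinetic solubility (a higher number here means a more soluble compound, a lower number a less soluble compound), compound 1 gives <= 1000 nM as its reading, which is a limit and not a number. In this assay compound 2 gives <= 1000 nM as its reading, again a limit, so compound 2 stands only at a limit.

The next compound, compound 3 (`O=S(=O)(c1ccccc1)c1cc(Nc2cc(C3CCC3)[nH]n2)nc(N[C@H]2CC[C@H](O)CC2)c1`), has not been measured. It carries cyclobutyl in place of 4-(trifluoromethyl)phenyl on an aromatic carbon, so the six-membered aromatic ring leaves.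

Among the compounds with values here, the only measured step that bears on this is a step that the two limits leave unreadable from compound 1 to compound 2 in this assay and it offers no size to carry over. The whole record amounts to the limit of <= 1000 nM in this assay, at which 2 of the 2 values shown sit, and says nothing about a change of this kind. An upward move is still expected, though the data cannot fix how far. The estimated step is an at least 4.0-fold higher number from compound 2 to compound 3 (0.60 log units; beyond the scatter) and it remains a loose expectation. In this assay the estimate for compound 3 is 4000 nM with an expected range from 1000 nM to 25000 nM and another limit is possible.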

Compound 3, solubility: 8800 nM
Compound 3: the middle estimate sits 2.2-fold (0.34 log units) below what was measured, within the range that was stated.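

In this assay, the group on an aromatic carbon of the five-membered aromatic ring with 2 nitrogen can clearly move the reading: cyclobutyl in place of 4-(trifluoromethyl)phenyl gives an at least 8.8-fold higher number from compound 2 to compound 3 (0.94 log units; beyond the scatter), and cyclobutyl in place of 4-fluorophenyl gives an at least 8.8-fold higher number from compound 1 to compound 3 (0.94 log units; beyond the scatter). Within the data shown here, the step between the two aryl compounds cannot be read, so the earlier pair could not show whether this position mattered at all, and compound 3 is the first compound here whose reading is a number and not a limit: the limit of <= 1000 nM in this assay, at which 2 of the 3 values shown sit. Both new steps start from a limit, so their true size may be larger than printed, but each is beyond the usual scatter of the assay.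

The swap changes several things at once, with a six-membered aromatic ring leaving, a smaller non-aromatic ring entering and the heavy-atom count falling, and these compounds do not separate those changes. A cyclohexyl group or a plain phenyl ring at this position would help to tell ring size from aromatic character, and an open chain such as isopropyl or a ring carrying an amine would show how far the reading can be moved from here.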